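Placing fluorine and methoxy together on the aryl ring

This account rests on a few compounds, and the source may have more. Where it says the series, first, only, none or still open, it means among the compounds named here.

Measured compounds:
- compound 1 `CCC1=C(O)c2c(oc(-c3ccc(C)cc3)cc2=O)C(CC)(CC)C1=O` gives 39.2 uM in a functional assay on KB cells (Homo sapiens) for antiproliferative activity, read by sulforhodamine B assay, with a stated time of 3 days; a higher number here means that more compound is needed for the effect, a lower number that less compound is needed
- compound 2 `CCC1=C(O)c2c(oc(-c3ccc(OC)cc3)cc2=O)C(CC)(CC)C1=O` gives 17.7 uM
- compound 3 `CCC1=C(O)c2c(oc(-c3ccccc3F)cc2=O)C(CC)(CC)C1=O` gives > 56.2 uM, which is a limit of this assay and not a number

Compound 3 therefore stands at the limit of > 56.2 uM in this assay, at which 1 of the 3 values shown sits; only a limit is known for it. The step from compound 2 to compound 3 was an at least 3.1-fold higher number from compound 2 to compound 3 (0.50 log units; beyond the scatter), and from compound 1 to compound 2 it was a 2.2-fold lower number from compound 1 to compound 2 (0.35 log units; beyond the scatter), so among the measured compounds the one bearing a methoxy-substituted ring needs the least compound, while the 2-fluorophenyl compound could not be resolved.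

The new compound 4 `CCC1=C(O)c2c(oc(-c3ccc(OC)c(F)c3)cc2=O)C(CC)(CC)C1=O` is reached from compound 3 by the change (3-fluoro-4-methoxyphenyl in place of 2-fluorophenyl on an aromatic carbon). It keeps a fluorine on the ring but also brings in the methoxy that compound 2 carries. Within the data shown here, no measured pair shows what adding a fluorine beside such a methoxy does, so the expectation rests on compound 2 returning the lowest number and compound 3 sitting at the limit. Compound 4 is therefore expected to return a number again, roughly near compound 2, with the step from compound 3 estimated as an at least 2.2-fold lower number from compound 3 to compound 4 (0.35 log units; beyond the scatter). The estimate for compound 4 is 25 uM, within a range from 10 uM to 60 uM.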

Compound 4, concentration for half-maximal effect: 26.7 uM
The estimate for compound 4 lay 1.1-fold (0.03 log units) below the measured number; low and high end bracket the measured number.
By their numbers in this assay, from the lowest: compounds 2, 4 and 1 (each within the scatter of the next, the first and the last beyond it). At a limit, above all of these: compound 3.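

Compound 4 gives the first direct view of a fluorine added to the methoxy-bearing ring of compound 2 in this assay (a 1.5-fold higher number from compound 2 to compound 4 (0.18 log units; within the scatter)), and this step lies within the scatter, so the added fluorine produces no change that can be resolved here. Compound 4 returns a number, unlike the 2-fluorophenyl compound (an at least 2.1-fold lower number from compound 3 to compound 4 (0.32 log units; beyond the scatter)), so a fluorine on this aryl ring does not always go with a limit, while compound 4 also cannot be separated from the 4-methylphenyl compound (a 1.5-fold lower number from compound 1 to compound 4 (0.17 log units; within the scatter)), even though compound 1 and compound 2 stand apart. Among these compounds, compound 3 remains the only compound with a limit and not a number: the limit of > 56.2 uM in this assay, at which 1 of the 4 values shown sits.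

A 3-fluorophenyl ring without the methoxy is not among the compounds shown, so the separate parts played by the fluorine and the methoxy, and by the fluorine's position, stay open. Also open, from the compounds shown here alone, is whether an ethoxy group or an amine in place of the methoxy would lower the number or raise it.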